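A few compounds are considered here, and "the series" means these few. Any claim that something is new, unique, unknown or untested is made for them only; others in the source may bear on it.

The measured compounds and their values:

Compound 1, `CCOC(=O)c1cnc(-c2csc(C)n2)nc1NN1C(=O)C=C(C)C1=O`, gives 8000 nM in a functional assay on Jurkat cells for inhibition of nuclear factor NF-kappa-B complex (Homo sapiens); a lower number here means a stronger inhibitor, a higher number a weaker inhibitor.
Compound 2, `CCOC(=O)c1cnc(-c2cc3ccccc3s2)nc1NN1C(=O)C=C(C)C1=O`, gives 4000 nM in this assay.
Compound 3, `CCOC(=O)c1cnc(C(=O)c2ccco2)nc1NN1C(=O)C=C(C)C1=O`, gives 700 nM in this assay.

Compound 3 shows the lowest number of the three, and both of its steps from the others lie beyond the scatter: a 5.7-fold lower number from compound 2 to compound 3 (0.76 log units; beyond the scatter) and an 11-fold lower number from compound 1 to compound 3 (1.06 log units; beyond the scatter). In both steps a ring attached directly to the shared core was exchanged for a ring joined through a carbonyl, and the number fell.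

Compound 4, `CCOC(=O)c1cnc(Cc2ccccc2)nc1NN1C(=O)C=C(C)C1=O`, takes the next step: benzyl in place of (furan-2-yl)carbonyl on an aromatic carbon. Here the carbonyl and the furan ring both leave, and a benzyl group takes their place.

The two measured steps bear on this only in part. For the measured compounds named here, they show that the carbonyl-linked group gave the lowest number, but no measured compound carries a benzyl or any other group joined through a single saturated carbon. Since the element that marked out compound 3 is removed, the expectation is a step back toward the higher numbers of compound 1 and compound 2, of modest size: a 4.3-fold higher number from compound 3 to compound 4 (0.63 log units; beyond the scatter) is the expected step. Compound 4 is therefore estimated at 3000 nM in this assay, with a range from 800 nM to 12000 nM.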

Compound 4, half-maximal inhibitory concentration: 7000 nM
For compound 4 the middle estimate is 2.3-fold (0.37 log units) below the measured one, and the stated range covers the measured number.
By their numbers in this assay, from the lowest: compound 3; then compounds 2, 4 and 1 (each within the scatter of the next).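

In this assay, putting benzyl in place of (furan-2-yl)carbonyl on this aromatic carbon, between two ring nitrogen atoms, gives a 10-fold higher number from compound 3 to compound 4 (1.00 log units; beyond the scatter) even though both groups have the same heavy-atom count; the entering group is carbon only and has no hydrogen-bond acceptors. Benzyl also brings the first link through a single saturated carbon, yet this link does not set the compound apart from those with a ring attached directly, with a 1.8-fold higher number from compound 2 to compound 4 (0.24 log units; within the scatter) and a 1.1-fold lower number from compound 1 to compound 4 (0.06 log units; within the scatter), so among these four only the carbonyl-linked furan of compound 3 stands out. Nothing shown here measures a property that could account for these differences.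

On these data alone, the carbonyl and the furan ring left together, so it remains open which of them goes with the lower number of compound 3; benzoyl, which keeps the carbonyl with a benzene ring, and furan-2-ylmethyl, which keeps the furan on a saturated carbon, would tell them apart. Also open, as far as these compounds go, is how a group without any ring, such as a simple amine or a longer alkyl chain, would behave at this position.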